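The compounds below may be only part of what the source reports. "The series", "measured", "known", "first", "only" and "open" are said of these compounds alone.

Working notes on the series. In a functional assay on MDA-MB-436 cells (Homo sapiens) for antiproliferative activity, read by MTT assay, with a stated time of 48 h (on this read-out lower numbers stand for stronger inhibition and higher numbers for weaker inhibition), compound 1 `C=CS(=O)(=O)N1CCN(c2ncnc3sc(-c4ccc(C#N)cc4)cc23)CC1` gives 9170 nM and compound 2 `C=CS(=O)(=O)N1CCN(c2ncnc3sc(-c4cn(C)nc4C(F)(F)F)cc23)CC1` gives 15100 nM. Going by the values given here, these are the only two numeric readings so far, and a 1.6-fold higher number from compound 1 to compound 2 (0.22 log units; within the scatter) leaves them level. Compound 3 `C=CS(=O)(=O)N1CCN(c2ncnc3sc(C4=CCCCC4)cc23)CC1` gives only a limit of the assay, > 50000 nM. The other two steps, an at least 5.4-fold higher number from compound 1 to compound 3 (0.73 log units; beyond the scatter) and an at least 3.3-fold higher number from compound 2 to compound 3 (0.51 log units; beyond the scatter), rest on (the limit of > 50000 nM in this assay, at which 1 of the 3 values shown sits).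

Compound 4 `C=CS(=O)(=O)N1CCN(c2nc(OC[C@H]3CCCN3C)nc3sc(-c4ccc(C#N)cc4)cc23)CC1` keeps the 4-cyanophenyl group of compound 1 and differs by (1-methylpyrrolidin-2-yl)methoxy in place of hydrogen on an aromatic carbon, between two ring nitrogen atoms. All three measured steps exchange the 4-cyanophenyl group or its replacements, so none of them tests this place, and they give no direct size or direction for the change in this assay. With compound 1 at 9170 nM as the only anchor, no step beyond the scatter is expected, though the uncertainty is wide in both directions. The expected outcome is a 1.3-fold lower number from compound 1 to compound 4 (0.12 log units; within the scatter). The estimate for compound 4 is 7000 nM, with an expected range of 1800 nM to 28000 nM.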

Compound 4, half-maximal inhibitory concentration: 2290 nM
Estimate against measurement, compound 4: 3.1-fold (0.49 log units) above; measured number inside the range.
By their numbers in this assay, from the lowest: compound 4; then compounds 1 and 2 (each within the scatter of the next). At a limit, above all of these: compound 3.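

In this assay, the position between two ring nitrogen atoms accepts a substituent of 8 heavy atoms, and the change gives a 4.0-fold lower number from compound 1 to compound 4 (0.60 log units; beyond the scatter). Going by these compounds alone, this is the first step with a lower number beyond the scatter that rests on two numeric readings rather than on a limit, and it is read with the 4-cyanophenyl group held fixed. No measured property in the data shown accounts for this step.

On these data alone, whether a plain methoxy group or an open-chain dimethylaminoethoxy group at this position would give a similar step stays open, as does the part played by the N-methyl group and the defined stereocentre. Also open, as far as these compounds go, is whether the step carries over to the 1-methyl-3-(trifluoromethyl)-1H-pyrazol-4-yl group of compound 2.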